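A few compounds are considered here, and "the series" means these few. Any claim that something is new, unique, unknown or untested is made for them only; others in the source may bear on it.

Among the measured compounds shown here, compound 3 `COC(=O)c1cccc(C2(CNC(=O)Nc3c(C(C)C)cccc3C(C)C)CCCC2)c1` gives 34 nM in an assay on microsomes for inhibition of acyl-CoA:cholesterol acyltransferase (Oryctolagus cuniculus) (on this read-out lower numbers stand for stronger inhibition and higher numbers for weaker inhibition), the highest of the three numbers measured so far, though its distance from compound 2 `CC(C)c1cccc(C(C)C)c1NC(=O)NCC1(c2ccc(NCCO)cc2)CCCC1` at 25 nM and from compound 1 `CC(C)c1cccc(C(C)C)c1NC(=O)NCC1(c2cccc(N)c2)CCCC1` at 21 nM stays within the scatter. Compound 4 `CC(C)c1cccc(C(C)C)c1NC(=O)NCC1(c2ccc(C(=O)O)cc2)CCCC1` differs from compound 3 in one place: 4-carboxyphenyl in place of 3-(methoxycarbonyl)phenyl on a saturated ring carbon. For the measured compounds named here, three measured steps bear on this kind of change on the same saturated ring carbon: a 1.6-fold higher number from compound 1 to compound 3 (0.21 log units; within the scatter), a 1.4-fold higher number from compound 2 to compound 3 (0.13 log units; within the scatter) and a 1.2-fold higher number from compound 1 to compound 2 (0.08 log units; within the scatter), each within the scatter. Three exchanges of the group on that carbon have therefore left this assay essentially unchanged, so the step of a 1.2-fold higher number from compound 3 to compound 4 (0.07 log units; within the scatter) is expected to stay within the scatter as well. Compound 4 is estimated at 40 nM, between 15 nM and 120 nM.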

Compound 4, half-maximal inhibitory concentration: 3100 nM
Beside the measured number, compound 4's estimate is 78-fold (1.89 log units) below it; measured number outside the range, above it.
By their numbers in this assay, from the lowest: compounds 1, 2 and 3 (each within the scatter of the next); then compound 4.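

In this assay, among the compounds shown here, this saturated ring carbon proves far less forgiving than the earlier compounds suggested, since 4-carboxyphenyl alone breaks away: a 91-fold higher number from compound 3 to compound 4 (1.96 log units; beyond the scatter), alongside a 120-fold higher number from compound 2 to compound 4 (2.09 log units; beyond the scatter) and a 150-fold higher number from compound 1 to compound 4 (2.17 log units; beyond the scatter). Compounds 1, 2 and 3 carry quite different groups there and stay within the scatter of one another, so tolerance at this carbon does not extend to every group. Nothing available explains this sharp weakening. As far as these compounds go, whether 3-carboxyphenyl or 4-(methoxycarbonyl)phenyl would sit with compound 3 or with compound 4 stays open, so the free carboxy group cannot yet be separated from its placement on the phenyl ring.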